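The source may report more compounds than this note shows. Statements on the series, on what has been measured and on what is new or still open speak of the compounds shown alone.

Measured so far:
compound 1 `CCCC(C)Oc1ccc(C(=O)/C=C/c2c(/C=C/c3ccc(OC)cc3)cc(OC)cc2OC)cc1` — 9.4 ug/mL
compound 2 `CCCCCCOc1ccc(C(=O)/C=C/c2c(/C=C/c3ccc(OC)cc3)cc(OC)cc2OC)cc1` — 8.4 ug/mL
compound 3 `COc1ccc(/C=C/c2cc(OC)cc(OC)c2/C=C/C(=O)c2ccc(C)cc2C)cc1` — 0.3 ug/mL

All three were read in a functional assay on A549 cells (Homo sapiens) for antiproliferative activity, read by MTT assay, with a stated time of 48 h; a higher number here means a weaker inhibitor, a lower number a stronger inhibitor. Compound 2 stands second highest of the three numbers; its nearest neighbour is compound 1, and the two differ only in hexyl in place of 1-methylbutyl on an oxygen on an aromatic ring, a change that gave a 1.1-fold lower number from compound 1 to compound 2 (0.05 log units; within the scatter). The furthest is compound 3, which carries a 2,4-dimethylphenyl in place of 4-(1-methylbutoxy)phenyl on the carbonyl carbon relative to compound 1, a change that gave a 31-fold lower number from compound 1 to compound 3 (1.50 log units; beyond the scatter).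

Compound 4 `CCN(CC)c1ccc(C(=O)/C=C/c2c(/C=C/c3ccc(OC)cc3)cc(OC)cc2OC)cc1` has not yet been run in this assay. Compared with compound 2 it differs by diethylamino in place of hexyloxy on an aromatic carbon, on an aromatic carbon of a six-membered aromatic ring of carbon only, para to a large group.

Within the data shown here, no measured step changes the group at this position to anything other than an alkoxy chain. The step from compound 1 to compound 2 shows that two alkoxy chains of different shape give numbers within the scatter of each other; the step from compound 1 to compound 3 shows that the aryl attached to the carbonyl can move the number a great deal, but it swaps the whole aryl rather than one substituent. The step from compound 2 to compound 4 in this assay is therefore expected to be modest and of uncertain direction, with a lean towards a lower number: a 2.1-fold lower number from compound 2 to compound 4 (0.32 log units; beyond the scatter). Compound 4 is estimated to give about 4 ug/mL, within a range from 0.8 ug/mL to 15 ug/mL.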

Compound 4, half-maximal inhibitory concentration: 5.4 ug/mL
The estimate for compound 4 lay 1.4-fold (0.13 log units) below the measured number; the measured number falls inside the stated range.
By their numbers in this assay, from the lowest: compound 3; then compounds 4, 2 and 1 (each within the scatter of the next).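

In this assay, among these compounds, diethylamino is the first group at this position joined through nitrogen rather than oxygen, and it gives a 1.6-fold lower number from compound 2 to compound 4 (0.19 log units; within the scatter) against hexyloxy and a 1.7-fold lower number from compound 1 to compound 4 (0.24 log units; within the scatter) against 1-methylbutoxy, so this assay does not separate the nitrogen-linked group from either oxygen-linked chain. The aryl change remains large, with an 18-fold higher number from compound 3 to compound 4 (1.26 log units; beyond the scatter) for 4-(diethylamino)phenyl in place of 2,4-dimethylphenyl on the carbonyl carbon, so none of the three groups at this position, on the core shared by compounds 1, 2 and 4, comes near the number of compound 3. Nothing available bears on the reason for any of these numbers.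

Open, on these data alone, is whether a much smaller group at this position, such as a single methyl, a primary amine or a carboxylic acid, would give a number closer to that of compound 3 at 0.3 ug/mL and thus show how much of that large step belongs to this position. Also open, as far as these compounds go, is whether a cyclic amine such as pyrrolidine or morpholine in place of diethylamino would stay within the scatter of compound 4 or move away from it.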